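Replacing the Acetylfuran Group of Compound 2

The source may report more compounds than this note shows. Statements on the series, on what has been measured and on what is new or still open speak of the compounds shown alone.

In an in vitro ADME assay on microsomes from liver (Simiiformes) (on this read-out higher numbers stand for a longer-lived compound and lower numbers for a shorter-lived compound), compound 1 `Cc1cc(-c2noc(C(F)(F)F)n2)cc(C)c1OCCCc1cc(CO)no1` gives > 2.5 h, which is a limit and not a number. Going by the values given here, compound 2 `CC(=O)c1ccc(CCCOc2c(C)cc(-c3noc(C(F)(F)F)n3)cc2C)o1` gives 1.05 h, the only exact number so far. Compound 3 `Cc1ccc(CCCOc2c(C)cc(-c3noc(C(F)(F)F)n3)cc2C)cn1` carries 6-methylpyridin-3-yl in place of 5-acetylfuran-2-yl on the same chain carbon: 6-methylpyridin-3-yl in place of 5-acetylfuran-2-yl on a saturated chain carbon, three bonds along the chain from an oxygen on an aromatic ring. Among the compounds with values here, one measured step bears on this place, an at least 2.3-fold lower number from compound 1 to compound 2 (0.37 log units; beyond the scatter), and it lies beyond the scatter, so a swap here can shift the half-life. The expected step, a 1.3-fold higher number from compound 2 to compound 3 (0.12 log units; within the scatter), is small, slightly upward and within the scatter. For compound 3 the estimated half-life is 1.4 h, with an expected range from 0.6 h to 2.5 h.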

Compound 3, half-life: 1.97 h
For compound 3 the middle estimate is 1.4-fold (0.15 log units) below the measured one; the measured number falls inside the stated range.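

On this saturated chain carbon, the half-life does not separate 6-methylpyridin-3-yl from 5-acetylfuran-2-yl: a 1.9-fold higher number from compound 2 to compound 3 (0.27 log units; within the scatter). The swap from 3-(hydroxymethyl)-1,2-oxazol-5-yl gives an at least 1.2-fold lower number from compound 1 to compound 3 (0.10 log units; that floor lies within the scatter), so unlike compound 2, compound 3 is not shown to fall short of compound 1. From the compounds shown here alone, the true size of that gap stays unknown, because compound 1 carries a limit and not a number: the limit of > 2.5 h in this assay, at which 1 of the 3 values shown sits. Whether the methyl on the pyridine matters remains open, since only this one pyridine is shown. So does the effect of a plain phenyl ring, an amine or a longer chain.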